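Fluoro on the core of compound 1: permeability outlook

The source may hold more compounds than are shown below. What is called first, only, known or untested is meant among the compounds shown, and "the series" means these compounds.

Compound 1 (`CC(C)COc1ncc(-c2cn(C)c3cc(C(=O)NS(C)(=O)=O)ccc23)cc1Cl`) is the starting point, and in an ADME assay on Caco-2 cells (Homo sapiens) for permeability, in the apical to basolateral direction (on this read-out lower numbers stand for lower permeability and higher numbers for higher permeability), compound 1 gives < 15 nm/s. As far as these compounds go, that result is a limit of the assay and not a number, so the true position of compound 1 is unknown. The evidence on this point is the limit of < 15 nm/s in this assay, at which 1 of the 2 values shown sits. Compound 2 (`Cn1cc(-c2ccc(C(F)(F)F)cc2)c2cc(F)c(C(=O)NS(=O)(=O)C3CC3)cc21`) gives a measured 46 nm/s in this assay.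

Compound 3 (`CC(C)COc1ncc(-c2cn(C)c3cc(C(=O)NS(C)(=O)=O)c(F)cc23)cc1Cl`) carries one change from compound 1: fluoro in place of hydrogen on an aromatic carbon. Fluoro replaces hydrogen on an aromatic carbon, ortho to the (methylsulfonyl)carbamoyl group.

Among the compounds with values here, no measured pair differs in one place, so there is no direct precedent for this change. No shift beyond the scatter is expected in this assay, and no direction is favoured. The estimated step is a step that the limit leaves unreadable from compound 1 to compound 3. A reading reported only as a limit is also expected to be likely. For compound 3 the estimate is 12 nm/s, with an expected range of 5 nm/s to 30 nm/s.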

Compound 3, apparent permeability: 20 nm/s
The estimate for compound 3 lay 1.7-fold (0.22 log units) below the measured number, within the range that was stated.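

Working notes on the fluoro position: replacing hydrogen with fluoro ortho to the (methylsulfonyl)carbamoyl group gives the first readable single-place step in the series, which is an at least 1.3-fold higher number from compound 1 to compound 3 (0.12 log units; that floor lies within the scatter). Compound 3 also gives this substitution pattern a measured value on the scale of this assay, at 20 nm/s, so later single-place changes from compound 3 can be read as true steps in both directions. The reading for compound 1 remains a limit of the assay, so the step has a floor but no upper bound, and this change can be described only from that floor: the limit of < 15 nm/s in this assay, at which 1 of the 3 values shown sits.

Because that floor lies within the scatter, the compounds shown leave open whether fluoro at this position produces a real shift in this read-out, and a number for compound 1 would be needed to settle it. Also open, as far as these compounds go, is how this assay would read with a methoxy group or a nitrile on the same aromatic carbon, or with a carboxylic acid in place of the (methylsulfonyl)carbamoyl group.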